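Chloro on the fused ring of compound 2: an expected outcome

This account rests on a few compounds, and the source may have more. Where it says the series, first, only, none or still open, it means among the compounds named here.

Measured so far:
Compound 1, `CCCNNC(=O)c1ccc(CNC(=O)c2ccc3cnccc3n2)cc1`: in an assay on isolated protein for inhibition of protein deacetylase HDAC6 (Homo sapiens), read by fluorescence, with a stated time of 2 h (on this read-out higher numbers stand for weaker inhibition and lower numbers for stronger inhibition), compound 1 gives > 10000 nM, which is a limit of the assay and not a number.
Compound 2, `CCCNNC(=O)c1ccc(CNC(=O)c2cc3ccccc3[nH]2)cc1`: in this assay compound 2 gives > 10000 nM, again a limit and not a number.

Compound 2 therefore stands at the limit of > 10000 nM in this assay, at which 2 of the 2 values shown sit. Among the compounds with values here, no step between two measured compounds can be read from these values, since both sit at a limit and show only that neither reaches measurable inhibition.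

Compound 3, `CCCNNC(=O)c1ccc(CNC(=O)c2cc3cc(Cl)ccc3[nH]2)cc1`, differs from compound 2 in one place: chloro in place of hydrogen on an aromatic carbon. Within the data shown here, whether a chloro in place of hydrogen moves the read-out in this assay cannot be judged from compounds 1 and 2, as no measured pair shows such a change. With compound 2 at a limit, the step from compound 2 to compound 3 is expected to be none beyond the usual scatter, and is estimated as a step that the limit leaves unreadable from compound 2 to compound 3. Compound 3 is thus expected to give about 12000 nM, within 2500 nM to 50000 nM, most likely reported again as a limit.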

Compound 3, half-maximal inhibitory concentration: > 10000 nM
Compound 3 ended at the assay's limit (the forecaster's own chance of this, stated with the estimate: 70%); the middle value lies beyond the limit too.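

No step can be read from compound 2 to compound 3, since chloro in place of hydrogen leaves both compounds at a limit and not at a number: the limit of > 10000 nM in this assay, at which 3 of the 3 values shown sit.

The compounds shown leave open whether chloro in place of hydrogen has any effect on inhibition in this assay, and which change to the shared core would give a measurable value.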